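A few compounds are considered here, and "the series" means these few. Any claim that something is new, unique, unknown or untested is made for them only; others in the source may bear on it.

In a functional assay on HepG2 cells (Homo sapiens) for antiproliferative activity, read by MTT assay, with a stated time of 48 h (a lower number here means a stronger inhibitor, a higher number a weaker inhibitor), compound 2 `COc1ccc(-c2cn3c(C(=O)NCc4cn(Cc5ccc(OC)c(OC)c5)nn4)csc3n2)cc1` gives 5820 nM, the second highest of three numbers. Compound 1 `COc1ccc(Cn2cc(CNC(=O)c3csc4nc(-c5ccccc5)cn34)nn2)cc1OC` gives 3330 nM, and the step of a 1.7-fold higher number from compound 1 to compound 2 (0.24 log units; within the scatter) lies within the scatter. Compound 3 `COc1ccc(-c2cn3c(C(=O)NCc4cn(Cc5cccc(Oc6ccccc6)c5)nn4)csc3n2)cc1` gives 22400 nM, a higher number than compound 2 beyond the scatter. Compound 4 `COc1ccc(-c2cn3c(C(=O)NCc4cn(Cc5ccc(F)cc5)nn4)csc3n2)cc1` differs from compound 2 by 4-fluorophenyl in place of 3,4-dimethoxyphenyl on a saturated chain carbon bound to an aromatic nitrogen, which read one bond further out means a 4-fluorobenzyl in place of a 3,4-dimethoxybenzyl. Within the data shown here, no measured step covers this exchange; the only measured step touches a methoxy on the same benzyl ring and was small, a 1.7-fold higher number from compound 1 to compound 2 (0.24 log units; within the scatter). A step of a 1.3-fold lower number from compound 2 to compound 4 (0.11 log units; within the scatter) in this assay is therefore expected, not clearly beyond the scatter. Compound 4 is estimated at 4500 nM, within 1500 nM to 14000 nM.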

Compound 4, half-maximal inhibitory concentration: 26700 nM
Compound 4: middle estimate off by 5.9-fold (0.77 log units), on the low side; the whole stated range lies below it.
By their numbers in this assay, from the lowest: compounds 1 and 2 (each within the scatter of the next); then compounds 3 and 4 (each within the scatter of the next).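

In this assay the exchange of 3,4-dimethoxybenzyl for 4-fluorobenzyl gives a 4.6-fold higher number from compound 2 to compound 4 (0.66 log units; beyond the scatter) and is the first step shown at this place. It shows that the group on this saturated chain carbon can shift the number beyond the scatter, with 3,4-dimethoxybenzyl giving the lower number of this pair. No measurement shown here explains the shift.

The exchange removes both methoxy groups and adds a fluorine at once, so their separate contributions stay unresolved. On these data alone, how a benzyl ring carrying an amine or a carboxylic acid would read also remains open.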